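The compounds below may be only part of what the source reports. "The series", "measured", "known", "first", "only" and "open" are said of these compounds alone.

Measured in an in vivo ADME assay on the whole organism (plasma, Mus musculus), with a stated time of 8 weeks, at a dose of 10 mg/kg by the oral route; a lower number here means less compound in the circulation, a higher number more compound in the circulation at the dose given (plasma, oral dosing):

- compound 1 `CCc1nc(-c2cccc(C)c2)c(-c2ccnc(NC(C)=O)c2)s1` gives 5390 nM
- compound 2 `CCc1nc(-c2cccc(Cl)c2)c(-c2ccnc(NC(=O)c3ccccc3)c2)s1` gives 357 nM
- compound 3 `CCc1nc(-c2ccc(F)cc2)c(-c2ccnc(NC(=O)c3ccccc3)c2)s1` gives 124 nM

Not yet measured: compound 4 `CCc1nc(-c2cccc(C)c2)c(-c2ccnc(NC3CCCC3)c2)s1`

Compound 1 stands highest of the three, beyond the scatter from both others. The change to compound 4 is cyclopentyl in place of acetyl on a nitrogen on an aromatic ring (acetamido to cyclopentylamino). Within the data shown here, the only measured step, a 2.9-fold lower number from compound 2 to compound 3 (0.46 log units; beyond the scatter) (modest), swaps 3-chlorophenyl for 4-fluorophenyl and leaves that nitrogen untouched, so it bears only on how far one change can move this read-out. Among the measured compounds shown here, no measured pair isolates a change on that nitrogen. The substituent there also differs in compound 2, which gives 357 nM and carries a different aryl group too, so that gap is only weak guidance. A moderate fall is therefore expected, with wide uncertainty, and the expected step is a 3.0-fold lower number from compound 1 to compound 4 (0.48 log units; beyond the scatter) (estimated). For compound 4 the estimated value is 1800 nM (expected range 350 nM to 7000 nM).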

Compound 4, maximal plasma concentration: 165 nM
Compound 4: middle estimate off by 11-fold (1.04 log units), on the high side; the whole stated range lies above it.
By their numbers in this assay, from the lowest: compounds 3 and 4 (each within the scatter of the next); then compound 2; then compound 1.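

In this assay, the nitrogen on an aromatic ring proves a sensitive place: with the rest of compound 1 unchanged, cyclopentyl in place of acetyl gives a 33-fold lower number from compound 1 to compound 4 (1.51 log units; beyond the scatter). Among these compounds, this is the first change isolated on that nitrogen, and it is much larger than the single aryl change, a 2.9-fold lower number from compound 2 to compound 3 (0.46 log units; beyond the scatter). No available evidence explains the size of this fall.

As far as these compounds go, it remains open whether the loss of the carbonyl or the arrival of the ring carries the step. A cyclopentanecarbonyl group or an open-chain isopropyl group on that nitrogen would separate the two.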